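This account rests on a few compounds, and the source may have more. Where it says the series, first, only, none or still open, it means among the compounds named here.

Measured compounds in a physicochemical assay for lipophilicity, at pH 7.4; on this read-out higher numbers stand for higher lipophilicity and lower numbers for lower lipophilicity:

- compound 1 `OC1CN(c2cc(COc3ccc(F)c(F)c3F)nc(-c3ccccn3)n2)C1`: 2.8
- compound 2 `COC1(COc2cc(COc3ccc(F)c(F)c3F)nc(-c3ccccn3)n2)COC1`: 3.5

Compound 2 holds the higher of these two numbers, and the gap to compound 1 lies beyond the usual scatter of repeated measurements. The compound still to be measured is compound 3 `Fc1ccc(OCc2cc(OCC3(F)COC3)nc(-c3ccccn3)n2)c(F)c1F`. It differs from compound 2 in one place: fluoro in place of methoxy on a saturated ring carbon. Thus (3-methoxyoxetan-3-yl)methoxy becomes (3-fluorooxetan-3-yl)methoxy, and the rest of the molecule stays the same.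

Among the compounds with values here, only one measured step is available as a guide, a number 0.70 log units higher from compound 1 to compound 2 (beyond the scatter), and it is modest. It is a loose guide, since it exchanged a whole group on an aromatic carbon, while here only the methoxy is replaced. Within the data shown here, no measured pair shows fluoro in place of methoxy, so the direction stays uncertain. A smaller change in this assay than that modest step is expected, perhaps slightly upward. The estimated step is a number 0.10 log units higher from compound 2 to compound 3 (within the scatter), which may not stand clear of the scatter. For compound 3 the expected value is 3.6, with an estimated range of 3.2 to 4.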

Compound 3, distribution coefficient: 4
Compound 3: the middle estimate sits 0.40 log units below what was measured; the range from low to high includes it.
By their numbers in this assay, from the lowest: compound 1; then compound 2; then compound 3.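

In this assay, the saturated ring carbon of the four-membered ring proves sensitive to a small exchange: fluoro in place of methoxy gives a number 0.50 log units higher from compound 2 to compound 3 (beyond the scatter) and so clears the scatter. On the computed counts, methoxy has 2 heavy atoms and 1 hydrogen-bond acceptor while fluoro has 1 heavy atom and 0 hydrogen-bond acceptors, yet this step is rated modest, as is the exchange of a whole group in a number 0.70 log units higher from compound 1 to compound 2 (beyond the scatter) on an aromatic carbon. Replacing 3-hydroxyazetidin-1-yl on that aromatic carbon with (3-fluorooxetan-3-yl)methoxy gives a number 1.20 log units higher from compound 1 to compound 3 (beyond the scatter) and counts as a large step, which places compound 3 highest of the three in this series.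

The compounds shown leave open how a hydroxyl or an amine on the same ring carbon would read in this assay, and whether fluoro in place of methoxy would give a similar step on a different core. No measurement here accounts for the size or direction of these steps.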